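Cytotoxicity on Vero Cells: Ester in Place of Methoxy

This account rests on a few compounds, and the source may have more. Where it says the series, first, only, none or still open, it means among the compounds named here.

Compound 1 `Cc1ccc(-c2c(C#N)[n+]([O-])c3cc(Cl)ccc3[n+]2[O-])cc1` — in an ADME assay on Vero cells (Chlorocebus sabaeus) for cytotoxicity, read by MTT assay, with a stated time of 72 h (on this read-out lower numbers stand for stronger inhibition and higher numbers for weaker inhibition), compound 1 gives 0.63 ug/mL.
Compound 2 `COc1ccc(-c2c(C#N)[n+]([O-])c3cc(Cl)ccc3[n+]2[O-])cc1` — in this assay compound 2 gives "not determined" (no result reported), so no result is reported for it.

Compound 2 therefore stands nowhere on the numbers shown; only compound 1 carries a value, and nothing measured links the two. Compound 3 `COC(=O)c1ccc(-c2c(C#N)[n+]([O-])c3cc(Cl)ccc3[n+]2[O-])cc1` differs from compound 2 by methoxycarbonyl in place of methoxy on an aromatic carbon. Going by the values given here, with no measured step available, the size of the change in this assay cannot be read off, and a shift of about the usual scatter in either direction is as plausible as none. Among the compounds with values here, the only anchor is compound 1 at 0.63 ug/mL. Compound 3 is expected to give roughly 1 ug/mL, within 0.3 ug/mL to 4 ug/mL.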

Compound 3, half-maximal inhibitory concentration: 20.9 ug/mL
Estimate against measurement, compound 3: 21-fold (1.32 log units) below; measured number above the stated range.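

Methoxycarbonyl in place of methyl on the aromatic carbon para to a large group gives a 33-fold higher number from compound 1 to compound 3 (1.52 log units; beyond the scatter) in this assay. The group at this position therefore matters, and here methoxycarbonyl goes with weaker inhibition than methyl. Nothing in the data shown gives a reason for this shift.

With no result for compound 2, the change from methoxy to methoxycarbonyl cannot be read. From the compounds shown here alone, whether a carboxylic acid, an amine or a longer chain at this position would give a number nearer compound 1 or compound 3 remains open.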